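Methylcarbamoyl Replaces 2-Methylphenyl on a Sulfonamide Series

This account rests on a few compounds, and the source may have more. Where it says the series, first, only, none or still open, it means among the compounds named here.

Measured compounds:
compound 1, `COc1ccc(Cl)cc1S(=O)(=O)Nc1cncc(-c2ccccc2C)c1`, in an assay on isolated protein for inhibition of alkaline phosphatase, tissue-nonspecific isozyme (Homo sapiens); on this read-out lower numbers stand for stronger inhibition and higher numbers for weaker inhibition: "not determined" (no result reported)
compound 2, `COc1ccc(C#N)cc1S(=O)(=O)Nc1cnc2ccccc2c1`, in this assay: "not determined" (no result reported)
compound 3, `COc1ccc(Br)cc1S(=O)(=O)Nc1cccnc1`, in this assay: 543 nM

The account follows the step from compound 1 to compound 4, `CNC(=O)c1cncc(NS(=O)(=O)c2cc(Cl)ccc2OC)c1`. Compound 1 stands without a single number in this assay; compound 2 is in the same position. Going by the values given here, the only value in the set belongs to compound 3, which in this assay gives 543 nM, and compound 3 differs from compound 1 in more than one place, so it can serve only as a rough anchor for the shared core.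

The change from compound 1 to compound 4 is methylcarbamoyl in place of 2-methylphenyl on an aromatic carbon. Among the compounds with values here, no step between two measured compounds is available, so nothing in the data says how large a change of this kind shifts the read-out of this assay, nor in which direction. With compound 1 unmeasured, the expectation for compound 4 rests on the anchor of compound 3 alone, widened for the two differences between compound 3 and compound 4 and for the unknown effect of the exchange itself.

Compound 4 is therefore expected to give roughly 1500 nM in this assay, with a broad range from 300 nM to 8000 nM.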

Compound 4, half-maximal inhibitory concentration: > 20000 nM
Compound 4 was reported as a limit (the forecaster's own chance of this, stated with the estimate: 25%); middle value at least 13-fold (1.12 log units) from the limit.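

In this assay compound 4 gives > 20000 nM, which is a limit of the assay and not a number. Going by these compounds alone, compound 1 stands without a single number, so no step from compound 1 to compound 4 can be read. The compounds shown leave open how far, and in which direction, exchanging 2-methylphenyl for methylcarbamoyl shifts this read-out.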